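Carboxy in place of amino: what to expect

The source may report more compounds than this note shows. Statements on the series, on what has been measured and on what is new or still open speak of the compounds shown alone.

In an ADME assay on HepG2 cells (Homo sapiens) for cytotoxicity, with a stated time of 72 h (on this read-out lower numbers stand for an effect already at smaller amounts and higher numbers for an effect only at larger amounts of compound), compound 1 `Cc1cc(NC(=O)Nc2ccc(C(C)(C)C)cc2)c2ccccc2n1` gives 17000 nM, a measured number. Compound 2 `Cc1cc(NC(=O)Nc2ccc(N)cc2)c2ccccc2n1` gives > 25000 nM, which is a limit of the assay and not a number. The data so far therefore show (the limit of > 25000 nM in this assay, at which 1 of the 2 values shown sits), and compound 2 has no exact position on the scale.

The next structure, compound 3 `Cc1cc(NC(=O)Nc2ccc(C(=O)O)cc2)c2ccccc2n1`, carries carboxy in place of amino on an aromatic carbon, para to a large group (carboxy in place of amino on an aromatic carbon). Within the data shown here, the one measured step that bears on this change, amino in place of tert-butyl on an aromatic carbon, is an at least 1.4-fold higher number from compound 1 to compound 2 (0.16 log units; that floor lies within the scatter), so no step beyond the scatter is expected in this assay. That single step is thin support, and it involves a different pair of groups. Compound 3 may well be reported only as a limit too.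

The expected change is a step that the limit leaves unreadable from compound 2 to compound 3. For compound 3 the estimated value is 30000 nM, with an expected range from 15000 nM to 60000 nM.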

Compound 3, half-maximal effective concentration: > 25000 nM
Compound 3 ended at the assay's limit; the forecaster's own chance of this, stated with the estimate: 75%; the middle value is on the limit's open side.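

In this assay compound 3 gives > 25000 nM, which is a limit of the assay and not a number. What is new is that a second group at this place, para to a large group, ends at the same limit as amino, so swapping amino for carboxy gives no readable change, and the step between compound 2 and compound 3 cannot be read. The only step that can be read is an at least 1.4-fold higher number from compound 1 to compound 3 (0.16 log units; that floor lies within the scatter), and with only a floor its true size stays unknown, while the values now gather at one edge of the scale: the limit of > 25000 nM in this assay, at which 2 of the 3 values shown sit.

On these data alone, how compound 2 and compound 3 truly stand against each other stays open, as does whether any change at this place moves the number beyond the usual scatter from compound 1. A methoxy group or a longer alkyl chain at the same place would show whether a measured number can be obtained there, close to that of compound 1, or whether such a compound also ends at the limit.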